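Notes on the step from compound 2 to compound 3

A few compounds are considered here, and "the series" means these few. Any claim that something is new, unique, unknown or untested is made for them only; others in the source may bear on it.

Values in an ADME assay on microsomes from liver (Rattus norvegicus) for metabolic stability (a lower number here means that the compound disappears faster, a higher number that the compound lasts longer), for the measured compounds:
- Compound 1 `Nc1nc(NCCNc2ncc(-c3ncc[nH]3)c(-c3ccc(C(F)(F)F)cc3)n2)ccc1[N+](=O)[O-]` gives > 0.5 h (a limit)
- Compound 2 `Nc1nc(NCCNc2ncc(-c3ncc[nH]3)c(-c3ccccc3Br)n2)ccc1[N+](=O)[O-]` gives > 0.5 h (a limit)

Compound 2 stands at > 0.5 h and this is a limit, not a number. The evidence is thin: the limit of > 0.5 h in this assay, at which 2 of the 2 values shown sit, is all that the two compounds show.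

Compound 3 `Nc1nc(NCCNc2ncc(-c3ncc[nH]3)c(-c3ccc(F)cc3Cl)n2)ccc1[N+](=O)[O-]` carries 2-chloro-4-fluorophenyl in place of 2-bromophenyl on an aromatic carbon of the shared core.

Among the measured compounds shown here, the one measured step bearing on this change is a step that the two limits leave unreadable from compound 1 to compound 2 and it also exchanges the aryl group, so no size carries over. The expected move in this assay is a step that the limit leaves unreadable from compound 2 to compound 3 and nothing beyond the scatter is foreseen. Compound 3 is estimated at 0.7 h with a range of 0.4 h to 1.5 h and a further limit reading is likely.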

Compound 3, half-life: > 0.5 h
Compound 3: a limit, no number; the forecaster's own chance of this, stated with the estimate: 75%; the middle value is on the limit's open side.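

In this assay compound 3 gives > 0.5 h, a limit and not a number, and the steps to compound 3 from compound 2 and from compound 1 cannot be read. The actual half-lives of compound 1, compound 2 and compound 3, and any differences among them, remain open: the limit of > 0.5 h in this assay, at which 3 of the 3 values shown sit.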